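Replacing a cyano group on compound 3

The source may report more compounds than this note shows. Statements on the series, on what has been measured and on what is new or still open speak of the compounds shown alone.

In a functional assay on HL-60 cells (Homo sapiens) for antiproliferative activity, read by MTT assay, with a stated time of 48 h (on this read-out higher numbers stand for weaker inhibition and lower numbers for stronger inhibition), compound 3 (`CN(C)CCCCn1c(N)c(C#N)c2nc(C#N)c(C#N)nc21`) gives 12900 nM and stands highest of the two numbers available. Compound 1 (`N#Cc1nc2c(-c3nc4ccccc4[nH]3)c(N)n(CCN3CCCC3)c2nc1C#N`) gives 4760 nM in this assay and so lies lower, beyond the scatter. Compound 2 (`CCN(CC)CCCn1c(N)c(-c2nc3ccccc3[nH]2)c2nc(C#N)c(C#N)nc21`) gives > 730 nM and this is a limit, not a number.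

Compound 4 (`CN(C)CCCCn1c(N)c(-c2nc3ccccc3n2C)c2nc(C#N)c(C#N)nc21`) keeps the 4-(dimethylamino)butyl group of compound 3 but carries 1-methyl-1H-benzimidazol-2-yl in place of cyano on an aromatic carbon. Within the data shown here, the only measured step (a step that the limit leaves unreadable from compound 1 to compound 2) lies on the chain and has no readable size, so no measured step covers this change. Compound 1 and compound 2 hold the same kind of group at this carbon without the methyl, but their chains differ from that of compound 3. Among the measured compounds shown here, the one guide is compound 1 at its lower number (4760 nM), so a moderate fall is expected in this assay, with real uncertainty. The estimated change is a 3.7-fold lower number from compound 3 to compound 4 (0.57 log units; beyond the scatter) and it points towards stronger inhibition. The expected value for compound 4 is 3500 nM with an estimated range from 800 nM to 12000 nM (both ends expected, not measured).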

Compound 4, half-maximal inhibitory concentration: 740 nM
Estimate against measurement, compound 4: 4.7-fold (0.67 log units) above, outside the stated range (below it).
By their numbers in this assay, from the lowest: compound 4; then compound 1; then compound 3.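

Exchanging cyano for 1-methyl-1H-benzimidazol-2-yl on this aromatic carbon, with the 4-(dimethylamino)butyl group held in place, gives a 17-fold lower number from compound 3 to compound 4 (1.24 log units; beyond the scatter) in this assay. This is the first step with a readable size among the compounds shown, and it establishes that the group on this carbon, next to the ring atom that bears an amino group, can move the number a long way; the one earlier step lay on the chain and cannot be read. Among the compounds with numbers, compound 4 now sits lowest at 740 nM, so the large step leads to the lowest number in this short series.

Going by these compounds, compound 2 holds a limit and not a number, so its place relative to the others remains open: the limit of > 730 nM in this assay, at which 1 of the 4 values shown sits. Also open, on these data alone, is what the methyl of the 1-methyl-1H-benzimidazol-2-yl group contributes on the 4-(dimethylamino)butyl chain, and how an amine or a carboxylic acid on this aromatic carbon would compare with cyano and with 1-methyl-1H-benzimidazol-2-yl.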